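Swapping 4-methylpiperazin-1-yl for piperazin-1-yl on a shared core

A few compounds are considered here, and "the series" means these few. Any claim that something is new, unique, unknown or untested is made for them only; others in the source may bear on it.

Compound 1 `COc1ccc(-c2nc(N3CCNCC3)nc3ccccc23)c(OC)c1`: 50 ug/mL
Compound 2 `COc1cc(OC)c(-c2nc(N3CCN(C)CC3)nc3ccccc23)c(OC)c1`: 50 ug/mL

In a functional assay on C-33-A cells (Homo sapiens) for antiproliferative activity, read by MTT assay (on this read-out lower numbers stand for stronger inhibition and higher numbers for weaker inhibition), compound 2 gives 50 ug/mL, level with compound 1 within the usual scatter of repeat measurements. Compound 3 `COc1cc(OC)c(-c2nc(N3CCNCC3)nc3ccccc23)c(OC)c1` differs from compound 2 in one place: hydrogen in place of methyl on an amine nitrogen in a ring. Within the data shown here, no measured pair shows this change alone, so the guide is indirect. Compound 1 also bears piperazin-1-yl and gives 50 ug/mL. Expected here is no change at the digits printed from compound 2 to compound 3 (within the scatter), none beyond the scatter in this assay. For compound 3 the estimated value is 50 ug/mL, with an expected range from 25 ug/mL to 100 ug/mL.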

Compound 3, half-maximal inhibitory concentration: 50 ug/mL
Estimate against measurement, compound 3: no gap at the digits printed; the range from low to high includes it.
By their numbers in this assay, from the lowest: compounds 1, 2 and 3 (each within the scatter of the next).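

The direct pair in this assay isolates hydrogen in place of methyl on an amine nitrogen in a ring and gives no change at the digits printed from compound 2 to compound 3 (within the scatter), so this change alone stays within the scatter. Methoxy in place of hydrogen on an aromatic carbon, read with the piperazin-1-yl group held constant, gives no change at the digits printed from compound 1 to compound 3 (within the scatter), also within the scatter. No evidence on the cause of either result is available. Still open, going by these compounds, is whether an acetyl group or a longer chain ending in a carboxylic acid on that ring nitrogen would move the value beyond the scatter.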